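Sulfonylurea series: ring swap from compound 1 to compound 4

A few compounds are considered here, and "the series" means these few. Any claim that something is new, unique, unknown or untested is made for them only; others in the source may bear on it.

Compound 1 `O=C(Nc1ccc(Cl)cc1)NS(=O)(=O)c1cccs1` serves as the reference point. In a functional assay on the whole organism (6C3HED cells, Mus musculus) for inhibition, at a dose of 300 mg/kg by the oral route (on this read-out lower numbers stand for less inhibition and higher numbers for more inhibition at the one dose given (going by the name of the read-out)), compound 1 gives 66%, the highest of the three numbers on hand. Compound 2 `CC(C)c1ccc(S(=O)(=O)NC(=O)Nc2ccc(Cl)cc2)s1` gives 63%, and a number 3 percentage points lower from compound 1 to compound 2 (within the scatter) shows that isopropyl in place of hydrogen on an aromatic carbon leaves the read-out within the scatter. Compound 3 `CC(C)(C)c1ccc(S(=O)(=O)NC(=O)Nc2ccc(Cl)cc2)s1` gives 10%; a number 56 percentage points lower from compound 1 to compound 3 (beyond the scatter) and a number 53 percentage points lower from compound 2 to compound 3 (beyond the scatter) are both large drops. Compound 4 `CCc1ccc(S(=O)(=O)NC(=O)Nc2ccc(Cl)cc2)o1` differs from compound 1 by 5-ethylfuran-2-yl in place of thiophen-2-yl on a sulfonyl sulfur. For the measured compounds named here, no measured step alters the ring itself; the ethyl resembles the small alkyl of compound 2, and the step of a number 3 percentage points lower from compound 1 to compound 2 (within the scatter) stayed within the scatter, whereas the large drop a number 56 percentage points lower from compound 1 to compound 3 (beyond the scatter) accompanied tert-butyl. A step of a number 11 percentage points lower from compound 1 to compound 4 (beyond the scatter) is expected, not beyond the scatter. Compound 4 is estimated at 55%, with a range from 30% to 75%.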

Compound 4, a percentage reported as inhibition, in the whole organism at one dose (the size of the read-out at that dose, not a potency): 80%
Estimate against measurement, compound 4: 25 percentage points below; the measured number lies above the stated range.
By their numbers in this assay, from the lowest: compound 3; then compounds 2 and 1 (each within the scatter of the next); then compound 4.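

On the sulfonyl sulfur, 5-ethylfuran-2-yl in place of thiophen-2-yl gives a number 14 percentage points higher from compound 1 to compound 4 (beyond the scatter) in this assay and is the only step shown that rises beyond the scatter. It is also the only step shown that replaces the ring itself, so this position accepts a different five-membered aromatic ring with an alkyl group and keeps the read-out high. No available measurement accounts for this rise.

The step combines the ring exchange with the added ethyl, and the compounds shown do not separate the two. Unsubstituted furan-2-yl and ethyl-bearing thiophen-2-yl remain the open comparisons, as does a longer chain such as n-butyl on the furan.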